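The source may hold more compounds than are shown below. What is called first, only, known or untested is meant among the compounds shown, and "the series" means these compounds.

In a functional assay on mitochondria (Cricetulus griseus) for inhibition of Monoamine oxidase (Homo sapiens), tested at 0.3 uM (on this read-out higher numbers stand for a stronger effect at the one concentration tested and lower numbers for a weaker effect), compound 1 `CCOc1ccc2c(=O)c(-c3ccc(O)cc3)coc2c1` gives 64.8%, and compound 2 `O=c1c(-c2ccc(O)cc2)coc2cc(OCCCBr)ccc12` gives 51.1%, the lowest of the two numbers. Within the data shown here, the only measured step, a number 13.7 percentage points lower from compound 1 to compound 2 (beyond the scatter), came from bromomethyl in place of hydrogen on a saturated chain carbon. Compound 3 `O=C(O)CCCCCCOc1ccc2c(=O)c(-c3ccc(O)cc3)coc2c1` differs from compound 2 by 3-carboxypropyl in place of bromo on a saturated chain carbon, three bonds along the chain from an oxygen on an aromatic ring. Among the measured compounds shown here, no measured step covers such an exchange, so it offers little guidance. Compound 3 is therefore expected to give a number close to that of compound 2, the expected step being a number 1.1 percentage points lower from compound 2 to compound 3 (within the scatter), with an estimate of 50% and a range from 33% to 67%.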

Compound 3, a percentage reported as inhibition, at one concentration (the size of the read-out at that concentration, not a potency): 48.6%
Beside the measured number, compound 3's estimate is 1.4 percentage points above it; low and high end bracket the measured number.
By their numbers in this assay, from the lowest: compounds 3 and 2 (each within the scatter of the next); then compound 1.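

In this assay, exchanging bromo for 3-carboxypropyl on this saturated chain carbon gives a number 2.5 percentage points lower from compound 2 to compound 3 (within the scatter), so these two chain ends cannot be told apart here. Set against the plain ethoxy compound, adding 4-carboxybutyl gives a number 16.2 percentage points lower from compound 1 to compound 3 (beyond the scatter), a clear step of modest size. No evidence here explains these results. As far as these compounds go, whether an amine at the chain end would behave like bromo and the carboxylic acid remains open. So does whether a shorter chain carrying the acid would stay closer to compound 1.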